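Aryl sulfonate anilides: chloroacetamide replaced by chloropropyl urea

The source may report more compounds than this note shows. Statements on the series, on what has been measured and on what is new or still open speak of the compounds shown alone.

Measured so far in a functional assay on MCF7 cells (Homo sapiens) for antiproliferative activity, read by sulforhodamine B assay, with a stated time of 48 h; on this read-out lower numbers stand for stronger inhibition and higher numbers for weaker inhibition:
compound 1, `CCCC(=O)Nc1cccc(S(=O)(=O)Oc2ccccc2C(C)C)c1`, 9400 nM
compound 2, `CC(C)c1ccccc1OS(=O)(=O)c1ccc(NC(=O)CCl)cc1`, 2900 nM
compound 3, `O=C(CCl)Nc1ccc(S(=O)(=O)Oc2ccccc2I)cc1`, 2500 nM

Compound 2 stands second highest of the three numbers. Its nearest neighbour is compound 3, with a 1.2-fold lower number from compound 2 to compound 3 (0.06 log units; within the scatter), a change on the phenol side of the sulfonate. Among the compounds with values here, its furthest is compound 1, which has no single-point step to compound 2 and simply shows a higher number beyond the scatter.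

Compound 4 `CC(C)c1ccccc1OS(=O)(=O)c1ccc(NC(=O)NCCCCl)cc1` differs from compound 2 by (3-chloropropyl)amino in place of chloromethyl on a carbonyl carbon. Within the data shown here, no measured step touches this carbonyl carbon, so nothing bears directly on it; the one step that exists, a 1.2-fold lower number from compound 2 to compound 3 (0.06 log units; within the scatter), lies elsewhere and was within the scatter. The only acylamino variation present is in compound 1, whose number in this assay is higher than that of compound 2, but that comparison is confounded by a second difference and gives no clean guide.

Among the measured compounds shown here, with no direct precedent, the expectation for compound 4 is a modest move toward a higher number in this assay, a 2.1-fold higher number from compound 2 to compound 4 (0.32 log units; beyond the scatter), with wide uncertainty. Compound 4 is estimated at 6000 nM, within a range of 2000 nM to 20000 nM.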

Compound 4, half-maximal inhibitory concentration: 7400 nM
Compound 4: middle estimate off by 1.2-fold (0.09 log units), on the low side; the range from low to high includes it.
By their numbers in this assay, from the lowest: compounds 3 and 2 (each within the scatter of the next); then compounds 4 and 1 (each within the scatter of the next).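

In this assay, within the data shown here, the change to (3-chloropropyl)amino in place of chloromethyl on a carbonyl carbon gives the first clean step at this position, a 2.6-fold higher number from compound 2 to compound 4 (0.41 log units; beyond the scatter); the only earlier step, iodo in place of isopropyl on an aromatic carbon, gave a 1.2-fold lower number from compound 2 to compound 3 (0.06 log units; within the scatter). This carbonyl carbon is therefore a place where a single change moves the number beyond the scatter, and here that move is toward weaker inhibition, even though the entering group keeps one chlorine and adds one nitrogen and one hydrogen-bond donor. Nothing measured on hand explains the shift.

This single step changes the chain and the nitrogen together, so it leaves open which of them accounts for the move, and whether the chlorine matters at all. A propylamino group with no chlorine, a (2-chloroethyl)amino group or a longer chloroalkylamino chain on the same carbonyl carbon would separate these parts, while iodo in place of isopropyl on compound 4 would test whether the two changes act independently.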